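The source may hold more compounds than are shown below. What is called first, only, known or untested is meant among the compounds shown, and "the series" means these compounds.

Three sulfonamides carrying the same bis(trifluoromethyl)phenyl core have been measured in a functional assay on Capan-2 cells (Homo sapiens) for inhibition, read by MTT assay, with a stated time of 72 h; a lower number here means a stronger inhibitor of growth, a higher number a weaker inhibitor of growth. Compound 1 `O=S(=O)(NCCNCc1cccc2ccccc12)c1cc(C(F)(F)F)cc(C(F)(F)F)c1` gives 21000 nM. Compound 2 `CC(C)(C)c1ccc(CNCCCNS(=O)(=O)c2cc(C(F)(F)F)cc(C(F)(F)F)c2)cc1` gives 2100 nM, and compound 3 `O=S(=O)(NCCNCc1ccc(-c2ccccc2)cc1)c1cc(C(F)(F)F)cc(C(F)(F)F)c1` gives 2400 nM. Compound 2 thus shows the lowest of the three numbers; the gap to compound 3 lies within the scatter of the assay, so the two cannot be ordered, while the gap to compound 1 lies beyond it.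

Compound 4 `COc1ccc(CNCCCNS(=O)(=O)c2cc(C(F)(F)F)cc(C(F)(F)F)c2)cc1OC` has not yet been measured. It differs from compound 2 in one place: 3,4-dimethoxyphenyl in place of 4-(tert-butyl)phenyl on a saturated chain carbon bound to an amine nitrogen. For the measured compounds named here, no measured pair in this set isolates that change, so the size of its effect is not known from the data. Given that the tert-butyl compound 2 sits at the low end of the numbers seen, compound 4 is expected to give a somewhat higher number in this assay, the estimated step being a 2.4-fold higher number from compound 2 to compound 4 (0.38 log units; beyond the scatter). For compound 4 the estimate in this assay is 5000 nM, with a range from 1500 nM to 17000 nM.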

Compound 4, concentration for 50% growth inhibition: 15000 nM
Compound 4: the middle estimate sits 3.0-fold (0.48 log units) below what was measured, and the stated range covers the measured number.
By their numbers in this assay, from the lowest: compounds 2 and 3 (each within the scatter of the next); then compounds 4 and 1 (each within the scatter of the next).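

In this assay, for the compounds shown here, the change from 4-(tert-butyl)phenyl to 3,4-dimethoxyphenyl on a saturated chain carbon bound to an amine nitrogen gives a 7.1-fold higher number from compound 2 to compound 4 (0.85 log units; beyond the scatter), the first step in this set that isolates a single place. It shows that the number at this position depends on what the aromatic ring carries, even though the leaving and entering groups have the same count of heavy atoms and the same ring. The entering group adds hydrogen-bond acceptors, but nothing at hand explains the step.

As far as these compounds go, whether a single methoxy group would give a comparable step remains open. So does the effect of a chlorine atom, a hydroxyl group or a carboxylic acid on that ring, or of a longer chain in compound 2.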